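From cyclopropyl to 2-hydroxyethyl in compound 4

The compounds below may be only part of what the source reports. "The series", "measured", "known", "first", "only" and "open" are said of these compounds alone.

In an ADME assay on Caco-2 cells (Homo sapiens) for permeability, read by LC-MS, in the apical to basolateral direction, with a stated time of 2 h (on this read-out lower numbers stand for lower permeability and higher numbers for higher permeability), compound 1 `CCCN(CC1CCOC1)C(=O)c1cc(OC)c2oc(NCc3cccc(Cl)c3)nc2c1` gives 246 nm/s, compound 2 `COc1cc(C(=O)N2CCC(O)C(C)C2)cc2nc(NCc3cccc(Cl)c3)oc12` gives 84 nm/s, and compound 3 `COc1cc(C(=O)N2CC(C)C(O)CC2C2CC2)cc2nc(NCc3cccc(Cl)c3)oc12` gives 138 nm/s. The number for compound 3 stands within the usual scatter of both the others.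

Compound 4 `COc1cc(C(=O)N2CC(C)C(O)CC2CCO)cc2nc(NCc3cccc(Cl)c3)oc12` has 2-hydroxyethyl in place of cyclopropyl on a saturated ring carbon, next to the ring nitrogen (2-hydroxyethyl in place of cyclopropyl on a saturated ring carbon).

Going by the values given here, no measured step tests this swap directly. The closest is a 1.6-fold higher number from compound 2 to compound 3 (0.22 log units; within the scatter), which put cyclopropyl in place of hydrogen on that same carbon and stayed within the scatter. Among the compounds with values here, the only step beyond the scatter, a 2.9-fold lower number from compound 1 to compound 2 (0.47 log units; beyond the scatter), is modest and gained a ring bearing a hydroxy group. Compound 3 goes against reading that as a rule, since a 1.8-fold lower number from compound 1 to compound 3 (0.25 log units; within the scatter) also gained one and stayed within the scatter.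

The evidence is thin, but a modest fall is expected, a 2.3-fold lower number from compound 3 to compound 4 (0.36 log units; beyond the scatter). Compound 4 is estimated at 60 nm/s, with an expected range from 25 nm/s to 120 nm/s.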

Compound 4, apparent permeability: 9.4 nm/s
Beside the measured number, compound 4's estimate is 6.4-fold (0.81 log units) above it, and the stated range ends above it.
By their numbers in this assay, from the lowest: compound 4; then compounds 2, 3 and 1 (each within the scatter of the next, the first and the last beyond it).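

In this assay, the saturated ring carbon next to the ring nitrogen turns out to be sensitive to what it carries: a 15-fold lower number from compound 3 to compound 4 (1.17 log units; beyond the scatter) followed 2-hydroxyethyl in place of cyclopropyl, whereas cyclopropyl in place of hydrogen had stayed within the scatter. The fall does not rest on cyclopropyl as the point of comparison, since 2-hydroxyethyl in place of hydrogen gives an 8.9-fold lower number from compound 2 to compound 4 (0.95 log units; beyond the scatter) as well. The full change of the amide group gives a 26-fold lower number from compound 1 to compound 4 (1.42 log units; beyond the scatter) and is the largest gap in this set, unlike the earlier swaps to a hydroxy-bearing ring, which stayed near the scatter.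

Nothing available here explains the drop. The swap removes a ring and adds a hydroxy group at once, and an ethyl or 2-methoxyethyl group on that carbon would help tell these two changes apart.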